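Widening the Ether Substituent in Compound 3

This account rests on a few compounds, and the source may have more. Where it says the series, first, only, none or still open, it means among the compounds named here.

Of the compounds shown here, two sharing one core have been measured in an assay on cells for binding affinity to metabotropic glutamate receptor 2 (Homo sapiens), read by scintillation proximity assay; on this read-out higher numbers stand for weaker binding and lower numbers for tighter binding. Compound 1 `Cc1cc(Oc2ccc(-c3ccn4c(CC5CC5)nnc4c3Cl)cc2F)ccn1` gives 37.6 nM in this assay. Compound 2 `Cc1cc(Oc2ccc(-c3ccn4c(CC5CC5)nnc4c3C(F)(F)F)cc2F)ccn1` gives 9.2 nM in this assay. For the measured compounds named here, the single step between them, a 4.1-fold lower number from compound 1 to compound 2 (0.61 log units; beyond the scatter), is trifluoromethyl in place of chloro on an aromatic carbon. Compound 2 thus holds the lowest of the two numbers, with compound 1 the nearest, one step beyond the scatter away.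

Compound 3 `COc1ccc(COc2ccc(-c3ccn4c(CC5CC5)nnc4c3C(F)(F)F)cc2F)cn1` has not yet been measured in this assay. It differs from compound 2 in (6-methoxypyridin-3-yl)methyl in place of 2-methylpyridin-4-yl on an oxygen on an aromatic ring. Going by the values given here, no measured step touches this part of the molecule: the only step, from compound 1 to compound 2, alters a group on the core rather than the group on the oxygen, so it offers no direct guidance, and its size says nothing about a change of this kind. The expectation for compound 3 therefore rests on compound 2 alone. Compound 3 is expected to sit near compound 2, at an estimated 20 nM with a range from 4 nM to 120 nM. The estimated step of a 2.2-fold higher number from compound 2 to compound 3 (0.34 log units; beyond the scatter) is expected to be small, with the range wide on both sides.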

Compound 3, dissociation constant: 16 nM
The estimate for compound 3 lay 1.3-fold (0.10 log units) above the measured number; low and high end bracket the measured number.
By their numbers in this assay, from the lowest: compounds 2 and 3 (each within the scatter of the next); then compound 1.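

In this assay, for the compounds shown here, the exchange of 2-methylpyridin-4-yl for (6-methoxypyridin-3-yl)methyl on the oxygen gives a 1.7-fold higher number from compound 2 to compound 3 (0.24 log units; within the scatter), so this is the first reading of the group on the oxygen, and the larger group with its second hydrogen-bond acceptor leaves the number within the scatter of compound 2. The earlier step, a 4.1-fold lower number from compound 1 to compound 2 (0.61 log units; beyond the scatter), lay beyond the scatter but changed a group on the core, so only now does the series show that a substantial exchange at the oxygen can leave the binding number essentially where it stood. No supporting measurement bears on why the two groups read alike.

The single exchange alters the methoxy group, the methyl link and the ring attachment together, so the compounds shown do not separate what each of these contributes, nor whether they offset one another. Also open, from the compounds shown here alone, are how a simple amine or a carboxylic acid on the same oxygen would read, and whether chloro on the core in place of trifluoromethyl would give the same step with the (6-methoxypyridin-3-yl)methyl group in place.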